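A few compounds are considered here, and "the series" means these few. Any claim that something is new, unique, unknown or untested is made for them only; others in the source may bear on it.

Compound 1 `COc1cc(-c2nn(-c3cccc(NC(=O)c4cccc(C(F)(F)F)c4)c3)cc2-c2ccncc2)ccc1Cl` has the highest number of the two compounds measured in a functional assay on KM12 cells (Homo sapiens) for inhibition, read by sulforhodamine B assay, with a stated time of 48 h; a higher number here means a weaker inhibitor of growth, a lower number a stronger inhibitor of growth: compound 1 gives 1660 nM, while compound 2 `O=C(Nc1cccc(-n2cc(-c3ccncc3)c(-c3ccc(Cl)c(O)c3)n2)c1)Nc1cc(C(F)(F)F)cc(C(F)(F)F)c1` gives 506 nM, a lower number that lies beyond the usual scatter. Compound 3 `COc1cc(-c2nn(-c3cccc(NC(=O)c4ccccc4)c3)cc2-c2ccncc2)ccc1Cl` is compound 1 with a single change, (hydrogen in place of trifluoromethyl on an aromatic carbon), hydrogen in place of trifluoromethyl on an aromatic carbon. For the measured compounds named here, no measured pair shows this exact change, so the size of the step is uncertain. A modest rise in the number is expected, a 2.1-fold higher number from compound 1 to compound 3 (0.32 log units; beyond the scatter). Compound 3 is therefore estimated at about 3500 nM, within a range of 1200 nM to 10000 nM.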

Compound 3, concentration for 50% growth inhibition: 556 nM
Compound 3: the middle estimate sits 6.3-fold (0.80 log units) above what was measured; measured number outside the range, below it.
By their numbers in this assay, from the lowest: compounds 2 and 3 (each within the scatter of the next); then compound 1.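

Taking the trifluoromethyl off this aromatic carbon does not cost growth inhibition in this assay: hydrogen in its place gives a 3.0-fold lower number from compound 1 to compound 3 (0.48 log units; beyond the scatter). On the core of compound 1, then, the group is not needed at this position, and the plain benzoyl does better than the (3-(trifluoromethyl)phenyl)carbonyl. No measurement available here explains this step. As far as these compounds go, whether a fluorine, a methyl, a methoxy or an amine at this same position would lower the number further remains open, since only trifluoromethyl and hydrogen are compared here.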